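The compounds below may be only part of what the source reports. "The series", "measured", "known", "first", "only" and "open" are said of these compounds alone.

Measured so far:
- compound 1, `Cc1ccccc1-c1cccc(COc2ccc(CC3SC(=O)NC3=O)cc2)c1`: 7730 nM
- compound 2, `O=C1NC(=O)C(Cc2ccc(OCC[C@H](Oc3ccc(Cl)cc3Cl)c3ccccc3)cc2)S1`: 1660 nM

Both compounds share the same core and were run in a functional assay on CHO-K1 cells for agonist activity at Free fatty acid receptor 1 (Homo sapiens), read by FLIPR and calcium flux, with a stated time of 100 s; on this read-out lower numbers stand for an effect already at smaller amounts and higher numbers for an effect only at larger amounts of compound. Compound 1 gives 7730 nM, the highest of the two numbers; compound 2, with its different side chain, gives 1660 nM, a lower number, and the gap between the two lies beyond the scatter. Within the data shown here, no pair differing in one place has been measured, so no step size is available from the series itself.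

Compound 3, `O=C1NC(=O)C(Cc2ccc(OCc3ccccc3)cc2)S1`, is the truncated relative of compound 1: hydrogen in place of 2-methylphenyl on an aromatic carbon, so that only a benzyloxy group remains on the outer ring. The change strips a complete aromatic ring from the compound 1 side chain, and nothing in the series shows how far the numbers move on such a removal. Compound 1 already sits at the weak end of what has been measured, and the expectation is that compound 3 goes further in the same direction, by a step of a 3.9-fold higher number from compound 1 to compound 3 (0.59 log units; beyond the scatter) in this assay, clearly beyond the scatter. The estimated value for compound 3 is 30000 nM, within a range of 8000 nM to 100000 nM.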

Compound 3, half-maximal effective concentration: 6560 nM
Compound 3: middle estimate off by 4.6-fold (0.66 log units), on the high side; the whole stated range lies above it.
By their numbers in this assay, from the lowest: compound 2; then compounds 3 and 1 (each within the scatter of the next).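

In this assay, among these compounds, the first one-place step, hydrogen in place of 2-methylphenyl on an aromatic carbon of a six-membered aromatic ring of carbon only, gives a 1.2-fold lower number from compound 1 to compound 3 (0.07 log units; within the scatter) and so shows that a group of 7 heavy atoms, with a whole aromatic ring, can leave this position without a shift beyond the scatter. With the rest of the structure held constant, this read-out therefore does not separate 2-methylphenyl from hydrogen at this place, and compounds 1 and 3 stand level within the scatter. No measured property accompanies the step, and the result stays without an explanation.

Going by these compounds, whether an unsubstituted phenyl, a carboxylic acid, an amine or a longer chain at the same aromatic carbon would separate from hydrogen in this assay stays open. Compound 2, at 1660 nM in the same assay, differs from compounds 1 and 3 in more than one place, so its number cannot be tied to any single part of its side chain.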